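This account rests on a few compounds, and the source may have more. Where it says the series, first, only, none or still open, it means among the compounds named here.

In a functional assay on MCF7 cells (Homo sapiens) for antiproliferative activity, read by MTT assay, with a stated time of 48 h (a higher number here means a weaker inhibitor, a lower number a stronger inhibitor), compound 1 `Fc1ccc(-c2nn(-c3ccccc3)cc2-c2nc3cc(F)ccc3[nH]2)cc1` gives 950 nM and compound 2 `Cc1ccc2[nH]c(-c3cn(-c4ccccc4)nc3-c3ccc(F)cc3)nc2c1` gives 1120 nM. Among the compounds with values here, compound 2 therefore sits within the scatter of compound 1, the only other measured compound, and the two cannot be ranked. Compound 3 `Fc1ccc(-c2nn(-c3ccccc3)cc2-c2nc3cc(C(F)(F)F)ccc3[nH]2)cc1` has not yet been measured. It departs from compound 2 by a single change, trifluoromethyl in place of methyl on an aromatic carbon, in the six-membered aromatic ring of carbon only.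

Within the data shown here, one measured step bears on this change: a 1.2-fold higher number from compound 1 to compound 2 (0.07 log units; within the scatter). That step is methyl in place of fluoro on the same aromatic carbon. Among the measured compounds shown here, it is small, but it is thin evidence, since no compound with trifluoromethyl at this carbon has a measured value. The expectation in this assay is therefore no step beyond the scatter, in either direction. The expected step is a 1.2-fold lower number from compound 2 to compound 3 (0.09 log units; within the scatter). For compound 3 the estimated value is 900 nM. The estimated range runs from 350 nM to 2300 nM.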

Compound 3, half-maximal inhibitory concentration: 2130 nM
Beside the measured number, compound 3's estimate is 2.4-fold (0.37 log units) below it; measured number inside the range.
By their numbers in this assay, from the lowest: compounds 1, 2 and 3 (each within the scatter of the next, the first and the last beyond it).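

In this assay, the carbon carrying the varied group now shows that its substituent can matter: the change from fluoro to trifluoromethyl gives a 2.2-fold higher number from compound 1 to compound 3 (0.35 log units; beyond the scatter), so compound 3 is a weaker inhibitor than compound 1, though only modestly. The change from methyl to trifluoromethyl gives a 1.9-fold higher number from compound 2 to compound 3 (0.28 log units; within the scatter), which cannot be ranked, and since methyl could not be separated from fluoro either, the three groups form no clean order: only fluoro and trifluoromethyl stand apart, with methyl unresolved from both. No measurement is at hand that bears on why these two groups differ at this carbon.

The compounds shown leave open how this carbon responds to groups of another kind, such as a plain hydrogen, a methoxy group, an amine or a carboxylic acid, any of which would test whether the modest separation seen here extends into a wider trend. They also leave open whether trifluoromethyl in place of fluoro would read the same way on another carbon of this ring, as all three compounds vary at a single carbon on the shared core.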